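Compound 3 to compound 4: ethynyl for 1-benzofuran-2-yl

The compounds below may be only part of what the source reports. "The series", "measured", "known", "first", "only" and "open" are said of these compounds alone.

In a functional assay on K562 cells (Homo sapiens), read by MTT assay, with a stated time of 72 h (on this read-out higher numbers stand for weaker inhibition and lower numbers for stronger inhibition), compound 3 `CNc1ncnc2c1c(-c1cc3ccccc3o1)cn2[C@@H]1O[C@H](CO)[C@@H](O)[C@H]1O` gives > 20000 nM, which is a limit and not a number. Compound 2 `CNc1ncnc2c1c(-c1ccsc1)cn2[C@@H]1O[C@H](CO)[C@@H](O)[C@H]1O` gives > 20000 nM, which is also a limit. Among the compounds with values here, the numbers so far therefore show (the limit of > 20000 nM in this assay, at which 2 of the 3 values shown sit).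

The next structure is compound 4 `C#Cc1cn([C@@H]2O[C@H](CO)[C@@H](O)[C@H]2O)c2ncnc(NC)c12`, and the change is ethynyl in place of 1-benzofuran-2-yl on an aromatic carbon, a small ethynyl in place of the larger 1-benzofuran-2-yl on an aromatic carbon. Within the data shown here, the one measured step is a step that the two limits leave unreadable from compound 2 to compound 3; it concerns the group at this same place but gives no size to carry over.

The closest guide is compound 1 `C#Cc1cn([C@@H]2O[C@H](CO)[C@@H](O)[C@H]2O)c2ncnc(SC)c12`, which already carries ethynyl, with methylsulfanyl where compound 4 has methylamino. Compound 1 gives 30 nM. With that value of compound 1 in view, a large step towards stronger inhibition is expected, though its size remains uncertain and a result at the limit cannot be ruled out.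

The expected move is an at least 33-fold lower number from compound 3 to compound 4 (1.52 log units; beyond the scatter).

For compound 4 the estimate is 600 nM, with an expected range from 30 nM to 10000 nM.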

Compound 4, half-maximal inhibitory concentration: > 20000 nM
Compound 4 gave a limit, no number; the forecaster's own chance of this, stated with the estimate: 20%; at least 33-fold (1.52 log units) between middle value and limit.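

Compound 4 gives > 20000 nM in this assay, which is a limit and not a number. With methylamino on the core, ethynyl therefore joins thiophen-3-yl and 1-benzofuran-2-yl at this aromatic carbon, and the steps among these three compounds cannot be read, so ethynyl alone does not bring a measurable value here. The one readable step lies at the other place: methylamino in place of methylsulfanyl gives an at least 660-fold higher number from compound 1 to compound 4 (2.82 log units; beyond the scatter), which shows that, with ethynyl held fixed, the measured value of compound 1 depends on that group, while the methylamino compounds stay at one limit: the limit of > 20000 nM in this assay, at which 3 of the 4 values shown sit.

Still open, from the compounds shown here alone, is how thiophen-3-yl or 1-benzofuran-2-yl would read with methylsulfanyl on the core. Also open, going by these compounds, is how a plain amino group, a dimethylamino group or a methoxy group would read in place of methylamino with ethynyl kept.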